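Amide-for-ester swap on the sulfoxide side chain

A few compounds are considered here, and "the series" means these few. Any claim that something is new, unique, unknown or untested is made for them only; others in the source may bear on it.

Measured in an assay on isolated protein for inhibition of sodium-dependent dopamine transporter (Rattus norvegicus), read by radioligand binding; on this read-out lower numbers stand for stronger inhibition and higher numbers for weaker inhibition:
compound 1 `COCC[S+]([O-])CC1CN(C)CCC1c1ccc(Cl)cc1`: 15 nM
compound 2 `CC(=O)OCCSCC1CN(C)CCC1c1ccc(Cl)cc1`: 35 nM
compound 3 `CC(=O)OCC[S+]([O-])CC1CN(C)CCC1c1ccc(Cl)cc1`: 9 nM

Compound 3 gives the lowest number of the three in this assay, but its step from compound 1 is a 1.7-fold lower number from compound 1 to compound 3 (0.22 log units; within the scatter), so the two are not separable; compound 2 gives 35 nM, and the gap to compound 3 is beyond the scatter.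

Compound 4 `CN1CCC(c2ccc(Cl)cc2)C(C[S+]([O-])CC(=O)N(C)C)C1` carries the change (dimethylcarbamoyl in place of acetoxymethyl on a saturated chain carbon bound to a sulfur). Going by the values given here, no measured step touches this position on the carbon bound to the sulfur. Among the compounds with values here, the nearest precedent, a 1.7-fold lower number from compound 1 to compound 3 (0.22 log units; within the scatter), altered the chain end and stayed within the scatter; a 2.3-fold higher number from compound 1 to compound 2 (0.37 log units; beyond the scatter) replaced the whole chain and shifted modestly. Nothing here supports a change beyond the scatter, so compound 4 is expected near compound 3, an estimated step of a 1.3-fold higher number from compound 3 to compound 4 (0.12 log units; within the scatter). The estimate for compound 4 is 12 nM, range 4 nM to 36 nM.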

Compound 4, inhibition constant: 2880 nM
Compound 4: the middle estimate sits 240-fold (2.38 log units) below what was measured; measured number outside the range, above it.
By their numbers in this assay, from the lowest: compounds 3 and 1 (each within the scatter of the next); then compound 2; then compound 4.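

In this assay the side chain on the sulfoxide proves far less tolerant than compounds 1 to 3 suggested: the new side chain gives a 320-fold higher number from compound 3 to compound 4 (2.51 log units; beyond the scatter) and likewise a 190-fold higher number from compound 1 to compound 4 (2.28 log units; beyond the scatter). Going by these compounds alone, earlier steps were modest at most, so the chain-end changes gave no sign of a step this large. No evidence on hand bears on this loss. Going by these compounds, the change from 2-acetoxyethyl to (dimethylcarbamoyl)methyl alters both chain and end group, so which one carries the loss stays open. A longer chain ending in the same dimethylcarbamoyl group would separate the two.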